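From Fluoro to Acetamido: Expecting Little Change

The source may hold more compounds than are shown below. What is called first, only, known or untested is meant among the compounds shown, and "the series" means these compounds.

In a functional assay on HepG2 cells (Homo sapiens) for cytotoxicity, read by MTT assay, with a stated time of 24 h (a higher number here means a weaker inhibitor, a lower number a stronger inhibitor), compound 1 (`CC(=O)Nc1ccc(S(=O)(=O)N2C/C(=C\c3ccccc3F)C(=O)/C(=C/c3ccccc3F)C2)cc1`) gives 5840 nM and compound 2 (`N#Cc1ccc(/C=C2\CN(S(=O)(=O)c3ccc(F)cc3)C/C(=C\c3ccccc3F)C2=O)cc1`) gives 8180 nM here, two values within the usual scatter of each other. Compound 3 (`CC(=O)Nc1ccc(S(=O)(=O)N2C/C(=C\c3ccc(C#N)cc3)C(=O)/C(=C/c3ccccc3F)C2)cc1`) differs from compound 2 by acetamido in place of fluoro on an aromatic carbon. Going by the values given here, no measured pair shows this change alone, and only these two values are known, so no step beyond the scatter is expected in this assay for it. The expected step is small (a 1.3-fold lower number from compound 2 to compound 3 (0.10 log units; within the scatter)). For compound 3 the estimated value is 6500 nM with an expected range from 2800 nM to 15000 nM in this measurement.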

Compound 3, half-maximal inhibitory concentration: 4960 nM
For compound 3 the middle estimate is 1.3-fold (0.12 log units) above the measured one, within the range that was stated.
By their numbers in this assay, from the lowest: compounds 3, 1 and 2 (each within the scatter of the next).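

In this assay, going by these compounds alone, the first measured step for acetamido in place of fluoro on an aromatic carbon is a 1.6-fold lower number from compound 2 to compound 3 (0.22 log units; within the scatter) and so shows that this place, para to a large group, takes the acetamido group with no step beyond the scatter. Putting 4-cyanophenyl in place of 2-fluorophenyl on the double-bonded chain carbon gives a 1.2-fold lower number from compound 1 to compound 3 (0.07 log units; within the scatter) and also stays within the scatter. Nothing measured here speaks to the reason for these small steps. This single pair leaves open whether an amine, a carboxylic acid or a longer chain at the same place would also stay within the scatter.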